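The source may hold more compounds than are shown below. What is called first, only, known or untested is meant among the compounds shown, and "the series" means these compounds.

Three compounds have been measured in a functional assay on K562 cells (Homo sapiens) for inhibition, read by trypan blue exclusion, with a stated time of 72 h; on this read-out higher numbers stand for weaker inhibition and lower numbers for stronger inhibition:

Compound 1 `Cn1c(=O)c(S(=O)(=O)c2ccc(F)cc2)cc2cnc(Nc3ccc4occc4c3)nc21` gives 5000 nM.
Compound 2 `Cn1c(=O)c(S(=O)(=O)c2ccc(Cl)cc2)cc2cnc(Nc3cnc4ccccc4c3)nc21` gives 15000 nM.
Compound 3 `COC(=O)Cn1ccc2cc(Nc3ncc4cc(S(=O)(=O)c5ccc(F)cc5F)c(=O)n(C)c4n3)ccc21` gives 5000 nM.

Compound 2 stands with the highest number of the three; compound 1 and compound 3 both lie a step beyond the scatter below it, while compound 1 and compound 3 sit within the scatter of each other. Compound 4 `Cn1c(=O)c(S(=O)(=O)c2ccc(Cl)cc2)cc2cnc(Nc3cnc4[nH]ccc4c3)nc21` is the compound still to be measured. It differs from compound 2 by a group of 9 heavy atoms (7 carbon, 2 nitrogen; one five-membered aromatic ring with 1 hetero atom, one six-membered aromatic ring with 1 hetero atom) in place of a group of 10 heavy atoms (9 carbon, 1 nitrogen; one six-membered aromatic ring of carbon only, one six-membered aromatic ring with 1 hetero atom), on a nitrogen on an aromatic ring. Among the compounds with values here, no step between measured compounds that differ in a single place is available, so the size of this change can only be judged from the three numbers as they stand. Because compound 2 gives 15000 nM and compound 1 gives 5000 nM, a move towards stronger inhibition of moderate size, a little beyond the scatter, is expected, a 2.5-fold lower number from compound 2 to compound 4 (0.40 log units; beyond the scatter). Compound 4 is estimated at 6000 nM, with a range from 2000 nM to 20000 nM.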

Compound 4, half-maximal inhibitory concentration: 5000 nM
Compound 4: middle estimate off by 1.2-fold (0.08 log units), on the high side, and the stated range covers the measured number.
By their numbers in this assay, from the lowest: compounds 1, 3 and 4 (each within the scatter of the next); then compound 2.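

In this assay, the group on the nitrogen was changed from quinolin-3-yl to a group of 9 heavy atoms, giving a 3.0-fold lower number from compound 2 to compound 4 (0.48 log units; beyond the scatter). Within the data shown here, this is the first comparison here in which only one place differs, and it shows that the group on this nitrogen can shift the read-out beyond the scatter while the rest of compound 2 stays the same. The step is modest, and it combines a change from a six-membered aromatic ring of carbon only to a five-membered aromatic ring with 1 hetero atom with a gain from 0 to 1 hydrogen-bond donor, so these two features cannot be told apart.

No measured information bears on why the number falls. The compounds shown leave open how a simple phenyl ring carrying an amine or a carboxylic acid would behave on this nitrogen.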